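Removing the Acyl Group Entirely from the Lactone Series

The compounds below may be only part of what the source reports. "The series", "measured", "known", "first", "only" and "open" are said of these compounds alone.

Compound 1 `COc1ccc(/C=C/C(=O)OC[C@@H](OCc2ccccc2)[C@H]2OC(=O)C=C[C@H]2OCc2ccccc2)cc1` carries the 2-(4-methoxyphenyl)ethenyl ester, and in a functional assay on MCF7 cells (Homo sapiens) for antiproliferative activity, read by MTT assay, with a stated time of 6 days (a higher number here means a weaker inhibitor, a lower number a stronger inhibitor), compound 1 gives 1110 nM. Compound 2 `O=C1C=C[C@@H](OCc2ccccc2)[C@@H]([C@@H](COC(=O)/C=C/c2ccc(F)cc2)OCc2ccccc2)O1` differs only by a fluoro in place of methoxy on an aromatic carbon; in this assay compound 2 gives 3010 nM, the step being a 2.7-fold higher number from compound 1 to compound 2 (0.43 log units; beyond the scatter). Compound 3 `CC(=O)OC[C@@H](OCc1ccccc1)[C@H]1OC(=O)C=C[C@H]1OCc1ccccc1`, the acetate, gives 18900 nM in this assay and stands highest of the three numbers: a 17-fold higher number from compound 1 to compound 3 (1.23 log units; beyond the scatter) and a 6.3-fold higher number from compound 2 to compound 3 (0.80 log units; beyond the scatter). Both measured steps ending at compound 3 shorten the acyl group and raise the number.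

Compound 4 `O=C1C=C[C@@H](OCc2ccccc2)[C@@H]([C@@H](CO)OCc2ccccc2)O1` takes this one step further: hydrogen in place of acetyl on an oxygen on a saturated carbon. Going by the values given here, no measured pair removes the acyl entirely, so the two steps ending at compound 3 are the only guide; both run the same way, one large and one modest. A further rise in this assay, of modest size, is therefore expected for compound 4. Compound 4 is expected to give 40000 nM in this assay, with a range of 12000 nM to 120000 nM. This corresponds to an expected step of a 2.1-fold higher number from compound 3 to compound 4 (0.33 log units; beyond the scatter).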

Compound 4, half-maximal inhibitory concentration: 17600 nM
Compound 4: middle estimate off by 2.3-fold (0.36 log units), on the high side; low and high end bracket the measured number.
By their numbers in this assay, from the lowest: compound 1; then compound 2; then compounds 4 and 3 (each within the scatter of the next).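

In this assay, the acetate and the free hydroxy form are not told apart at this position (a 1.1-fold lower number from compound 3 to compound 4 (0.03 log units; within the scatter)), so the rise seen on shortening the acyl group to acetyl does not continue when the acetyl is removed. The large gap lies instead between the two esters carrying an aryl-substituted ethenyl group and the free hydroxy form (a 5.8-fold higher number from compound 2 to compound 4 (0.77 log units; beyond the scatter); a 16-fold higher number from compound 1 to compound 4 (1.20 log units; beyond the scatter)), which places compound 4 with compound 3 and apart from compound 1 and compound 2. Nothing available accounts for this.

Open, on these data alone, is whether a benzoyl ester, lacking the ethenyl link, or a hexanoyl ester, with a longer saturated chain, would fall with compound 3 and compound 4 or with compound 1 and compound 2. Also open, as far as these compounds go, is how an amide or an amine in place of the ester oxygen would read here.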